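Carbamate in place of a propylphenyl amide on one core

A few compounds are considered here, and "the series" means these few. Any claim that something is new, unique, unknown or untested is made for them only; others in the source may bear on it.

Compound 1, `CCN(CC)c1cc2[nH]c(C3CCCCC3)nc2cc1NC(=O)c1ccc(F)cc1`: in an ADME assay on Vero cells (Chlorocebus sabaeus) for cytotoxicity, read by resazurin assay, with a stated time of 3 days (on this read-out lower numbers stand for stronger inhibition and higher numbers for weaker inhibition), compound 1 gives > 100 ug/mL, which is a limit of the assay and not a number.
Compound 2, `CCCc1ccc(C(=O)Nc2cc3nc(C4CCCCC4)[nH]c3cc2N(CC)CC)cc1`: in this assay compound 2 gives "not determined" (no result reported).

Compound 2 therefore has no number at all in this assay. Among the measured compounds shown here, the only value in this small set is the limit of > 100 ug/mL in this assay, at which 1 of the 2 values shown sits, so compound 2 cannot be placed against anything measured. Compound 3, `CCOCCOC(=O)Nc1cc2nc(C3CCCCC3)[nH]c2cc1N(CC)CC`, differs from compound 2 in one place: 2-ethoxyethoxy in place of 4-propylphenyl on a carbonyl carbon, the 2-ethoxyethoxy group entering on a carbonyl carbon whose other neighbour is an amide-type nitrogen. For the measured compounds named here, no step between measured compounds exists here, so the size of the step from compound 2 to compound 3 in this assay can only be expected, and the expectation is no change beyond the usual scatter, with compound 3 most likely sitting at the same limit that compound 1 reaches. Compound 3 is expected to give about 100 ug/mL in this assay, within a range from 50 ug/mL to 200 ug/mL.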

Compound 3, half-maximal inhibitory concentration: > 100 ug/mL
Compound 3 was reported as a limit; the forecaster's own chance of this, stated with the estimate: 70%; the middle value lies on the limit itself.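

In this assay compound 3 gives > 100 ug/mL, a limit of the assay and not a number. Compound 1 sits at the same limit, so no step can be read from compound 1 or compound 2 to compound 3. Left open is how compound 1, compound 2 and compound 3 truly rank in this assay.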